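This account rests on a few compounds, and the source may have more. Where it says the series, first, only, none or still open, it means among the compounds named here.

Of the compounds shown here, three that share one core have been tested in a functional assay on SF-268 cells (Homo sapiens) for inhibition, read by sulforhodamine B assay, with a stated time of 48 h; on this read-out higher numbers stand for weaker inhibition of growth and lower numbers for stronger inhibition of growth. Compound 1, `O=C(Nc1cccc(-n2cc(-c3ccncc3)c(-c3ccc(Cl)c(O)c3)n2)c1)Nc1ccc(Cl)c(Cl)c1`, gives 1490 nM. Compound 2, `COc1cc(-c2nn(-c3cccc(NC(=O)c4cccc(C(F)(F)F)c4)c3)cc2-c2ccncc2)ccc1Cl`, gives 2130 nM. Compound 3, `O=C(Nc1cccc(-n2cc(-c3ccncc3)c(-c3ccc(Cl)c(O)c3)n2)c1)Nc1cc(C(F)(F)F)cc(C(F)(F)F)c1`, gives 846 nM. Among these three numbers compound 2 has the highest; its gap to compound 1 lies within the scatter, so no order can be read between those two, while its gap to compound 3 lies beyond the scatter, so compound 3 inhibits growth more strongly than compound 2.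

The next compound, compound 4, `COc1cc(-c2nn(-c3cccc(NC(=O)Nc4ccc(Cl)c(Cl)c4)c3)cc2-c2ccncc2)ccc1Cl`, has not yet been measured in this assay. It differs from compound 2 in one place: (3,4-dichlorophenyl)amino in place of 3-(trifluoromethyl)phenyl on a carbonyl carbon. Among the measured compounds shown here, no measured pair shows this exact change, so the size of its step can only be estimated. Compound 1 and compound 3 both carry a (3,4-dichlorophenyl)amino or a related arylamino group on the carbonyl carbon and give numbers of the same order as compound 2, so the step from compound 2 to compound 4 is expected to be small, a 1.4-fold lower number from compound 2 to compound 4 (0.15 log units; within the scatter), and not beyond the scatter. Compound 4 is therefore estimated at 1500 nM in this assay, with a likely range from 700 nM to 3200 nM.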

Compound 4, concentration for 50% growth inhibition: 1510 nM
Beside the measured number, compound 4's estimate is 1.0-fold (0.00 log units) below it; low and high end bracket the measured number.
By their numbers in this assay, from the lowest: compounds 3, 1, 4 and 2 (each within the scatter of the next, the first and the last beyond it).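

Across the carbonyl carbon, replacing 3-(trifluoromethyl)phenyl with (3,4-dichlorophenyl)amino brings in a hydrogen-bond donor that the leaving group lacks, and in this assay this gives a 1.4-fold lower number from compound 2 to compound 4 (0.15 log units; within the scatter), so this position accepts the exchange of one aromatic group for the other without a readable shift in growth inhibition. Among the compounds shown here, the result also provides the first matched look at the oxygen on the aromatic ring: with methyl in place of hydrogen there, the step is a 1.0-fold higher number from compound 1 to compound 4 (0.01 log units; within the scatter), so this small addition likewise leaves no readable mark on this measurement. No separate measurement on hand bears on either result.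

Every group shown on the carbonyl carbon contains a six-membered aromatic ring of carbon only, so the effect of a cyclohexylamino group or a morpholine at that position remains open. On the oxygen only hydrogen and methyl appear, which leaves open whether a longer chain, such as ethyl or propyl, or a 2-aminoethyl group would also fall within the scatter.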